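From compound 3 to compound 4: one phenyl group exchanged

The compounds below may be only part of what the source reports. "The series", "measured", "known", "first", "only" and "open" are said of these compounds alone.

Measured so far in a functional assay on MCF7 cells (Homo sapiens) for antiproliferative activity, read by CellTiter-Glo, with a stated time of 5 days (on this read-out lower numbers stand for stronger inhibition and higher numbers for weaker inhibition), for each compound:
- Compound 1 `N#Cc1cc(Cl)ccc1/C(=C(\c1ccc(/C=C/C(=O)O)cc1)c1ccc2scnc2c1)C1CCC1` gives 0.9 nM
- Compound 2 `O=C(O)/C=C/c1ccc(/C(=C(\c2ccccc2)C2CCC2)c2ccc(-c3cncs3)cc2)cc1` gives 9.2 nM
- Compound 3 `O=C(O)/C=C/c1ccc(/C(=C(\c2ccc(F)cc2Cl)C2CCC2)c2ccc(-c3cncs3)cc2)cc1` gives 4.2 nM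

Compound 3 holds the middle place of these three numbers. Compound 4 `N#Cc1cc(Cl)ccc1/C(=C(\c1ccc(/C=C/C(=O)O)cc1)c1ccc(-c2cncs2)cc1)C1CCC1` differs from it in one place, where 4-chloro-2-cyanophenyl takes the place of 2-chloro-4-fluorophenyl: 4-chloro-2-cyanophenyl in place of 2-chloro-4-fluorophenyl on a double-bonded chain carbon bound to a double-bonded chain carbon and a saturated ring carbon. Going by the values given here, the only measured step at this place is modest: a 2.2-fold lower number from compound 2 to compound 3 (0.34 log units; beyond the scatter). Compound 1 carries the incoming group and reads 0.9 nM, but it also differs from compound 3 elsewhere, so it offers only a loose hint. A similarly modest drop is therefore expected, an estimated 2.1-fold lower number from compound 3 to compound 4 (0.32 log units; beyond the scatter), in this assay. Compound 4 is estimated at 2 nM, with an expected range from 0.7 nM to 6 nM overall.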

Compound 4, half-maximal inhibitory concentration: 4.3 nM
The estimate for compound 4 lay 2.2-fold (0.33 log units) below the measured number; measured number inside the range.
By their numbers in this assay, from the lowest: compound 1; then compounds 3 and 4 (each within the scatter of the next); then compound 2.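

In this assay, swapping the substituted phenyl group at this place leaves the reading within the scatter (a 1.0-fold higher number from compound 3 to compound 4 (0.01 log units; within the scatter)), so the two substituted groups cannot be told apart here. Both read below the plain phenyl (a 2.1-fold lower number from compound 2 to compound 4 (0.33 log units; beyond the scatter)), while the larger step lies elsewhere, at the other aryl group (a 4.8-fold higher number from compound 1 to compound 4 (0.68 log units; beyond the scatter)). Nothing available explains either result. On these data alone, whether an amine on this phenyl ring would give a different reading remains open. So does whether the 1,3-benzothiazol-5-yl step would hold with 2-chloro-4-fluorophenyl at this place.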